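A second methoxy on compound 3

This account rests on a few compounds, and the source may have more. Where it says the series, first, only, none or still open, it means among the compounds named here.

Three compounds share one core and differ in the group on the carbonyl carbon. In a functional assay on a cell-free system (Platelet, plasma, Homo sapiens) for inhibition (a higher number here means a weaker inhibitor, a lower number a stronger inhibitor), compound 1 (`Cc1ccc(N(CCN2CCC(OCC(=O)O)CC2)C(=O)c2ccc(F)cc2)cc1`) gives 970 nM. Compound 2 (`Cc1ccc(N(CCN2CCC(OCC(=O)O)CC2)C(=O)c2ccc(C(F)(F)F)cc2)cc1`) reaches only a limit of the assay, > 10000 nM. Compound 3 (`COc1cccc(C(=O)N(CCN2CCC(OCC(=O)O)CC2)c2ccc(C)cc2)c1`) gives 32 nM, the lowest number of the three.

The steps between them are all large. The series shows an at least 10-fold higher number from compound 1 to compound 2 (1.01 log units; beyond the scatter). It also shows a 30-fold lower number from compound 1 to compound 3 (1.48 log units; beyond the scatter), and an at least 310-fold lower number from compound 2 to compound 3 (2.49 log units; beyond the scatter).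

Compound 4 (`COc1cccc(C(=O)N(CCN2CCC(OCC(=O)O)CC2)c2ccc(C)cc2)c1OC`) is built from compound 3 with one addition: methoxy in place of hydrogen on an aromatic carbon. This is methoxy in place of hydrogen on an aromatic carbon, so 3-methoxyphenyl becomes 2,3-dimethoxyphenyl.

Among the measured compounds shown here, no measured step adds a second group to this ring. Still, a 30-fold lower number from compound 1 to compound 3 (1.48 log units; beyond the scatter) shows that changes in this group can move the number far, so a rise beyond the scatter is expected, though a smaller one than those steps. The expected change is a 2.8-fold higher number from compound 3 to compound 4 (0.45 log units; beyond the scatter). For compound 4 the estimated value is 90 nM, within an expected range from 15 nM to 600 nM.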

Compound 4, half-maximal inhibitory concentration: 1600 nM
For compound 4 the middle estimate is 18-fold (1.25 log units) below the measured one; the whole stated range lies below it.
By their numbers in this assay, from the lowest: compound 3; then compounds 1 and 4 (each within the scatter of the next). At a limit, above all of these: compound 2.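

In this assay the added methoxy, ortho to a large group and ortho to a methoxy group, gives a 50-fold higher number from compound 3 to compound 4 (1.70 log units; beyond the scatter) and shows that one small addition at this place can cancel all the advantage of 3-methoxyphenyl. The comparison with the 4-fluorophenyl compound is a 1.6-fold higher number from compound 1 to compound 4 (0.22 log units; within the scatter) and leaves 2,3-dimethoxyphenyl and 4-fluorophenyl indistinguishable in this test. For compound 2 the assay gives only a limit of > 10000 nM and the step therefore reads an at least 6.2-fold lower number from compound 2 to compound 4 (0.79 log units; beyond the scatter) without an exact size.

As far as these compounds go, it remains open whether any added group at this place has the same effect, which a hydroxyl or an amine there could test, or whether it is specific to methoxy. The data shown offer no explanation for the size of this step.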